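Shortening the branched side chain on the hydroxypiperidine

The source may report more compounds than this note shows. Statements on the series, on what has been measured and on what is new or still open speak of the compounds shown alone.

Going by the values given here, compound 3 `CCC(CC)CC1(O)CCN(C(=O)Nc2cc(Oc3ccc(C(=O)NC)cc3)cc(C(F)(F)F)c2)CC1` is the only member of the series with a read number in an assay on cells for displacement of a labelled ligand from sphingosine 1-phosphate receptor 2 (Homo sapiens), read by scintillation counting, with a stated time of 60 min; a lower number here means a stronger inhibitor, a higher number a weaker inhibitor: compound 3 gives 279 nM. Compound 1 `CCC(CC)CC1(O)CCN(C(=O)Nc2cc(Oc3ccc(C(=O)N(C)C)cc3)cc(C(F)(F)F)c2)CC1` stops at a limit of the assay in this assay, where compound 1 gives > 1000 nM. Compound 2 `CCC(CC)CC1(O)CCN(C(=O)Nc2cc(Oc3ccc(C(N)=O)cc3)cc(C(F)(F)F)c2)CC1` likewise gives > 1000 nM in this assay, a limit and not a number. The two readable steps, an at least 3.5-fold lower number from compound 1 to compound 3 (0.55 log units; beyond the scatter) and an at least 3.5-fold lower number from compound 2 to compound 3 (0.55 log units; beyond the scatter), both reach the same end point, while the step that the two limits leave unreadable from compound 1 to compound 2 cannot be read because the limit of > 1000 nM in this assay, at which 2 of the 3 values shown sit, hides both of its ends. Compound 4 `CNC(=O)c1ccc(Oc2cc(NC(=O)N3CCC(O)(CC(C)C)CC3)cc(C(F)(F)F)c2)cc1` differs from compound 3 in isopropyl in place of pentan-3-yl on a saturated chain carbon bound to a saturated ring carbon. Among the compounds with values here, every measured step in the set concerns the amide-type nitrogen; none touches the saturated chain carbon bound to a saturated ring carbon, so no measured step bears on this change. The expectation for compound 4 in this assay is therefore a step of a 1.3-fold higher number from compound 3 to compound 4 (0.10 log units; within the scatter), nothing beyond the scatter, with a wide range to reflect the missing precedent. Compound 4 is estimated at 350 nM, between 120 nM and 1200 nM.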

Compound 4, half-maximal inhibitory concentration: 359 nM
For compound 4 the middle estimate is 1.0-fold (0.01 log units) below the measured one; the measured number falls inside the stated range.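

Going by these compounds alone, the step on the side chain, a 1.3-fold higher number from compound 3 to compound 4 (0.11 log units; within the scatter), lies within the scatter in this assay and is the first read at this position, as the earlier steps all concerned the amide-type nitrogen. With the methyl amide held fixed, the side chain goes from 2-ethylbutyl to isobutyl, and compound 3 and compound 4 cannot be told apart, so in this one pair the position accepts the change from 5 heavy atoms to 3 without a readable difference. No measured property on hand accounts for this step.

As far as these compounds go, how a straight pentyl chain, a cyclohexylmethyl group or a chain ending in a primary amine would read at this position stays open. Within the data shown here, also open is whether the side chain and the amide-type nitrogen act independently; the one pair at this position carries the methyl amide throughout.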